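Ethoxy for trifluoromethyl in a series at the limit

This account rests on a few compounds, and the source may have more. Where it says the series, first, only, none or still open, it means among the compounds named here.

Compound 1 `CCCCCCCCCCCCCCNc1nc(SCc2ccc(C(F)(F)F)cc2)nc2ccccc12` gives > 50000 nM in a functional assay on MCF7 cells (Homo sapiens) for cytotoxicity, read by MTT assay, with a stated time of 72 h (a higher number here means a weaker inhibitor, a lower number a stronger inhibitor), a limit of the assay.
Compound 2 `FC(F)(F)c1ccc(CSc2nc(N3CCCCC3)c3ccccc3n2)cc1` gives > 50000 nM in this assay, a limit of the assay.
Compound 3 `FC(F)(F)c1ccc(CSc2nc(Nc3ccccc3C(F)(F)F)c3ccccc3n2)cc1` gives > 50000 nM in this assay, a limit of the assay.

Compound 3 thus stands at the limit of > 50000 nM in this assay, at which 3 of the 3 values shown sit, and no number is known for it in this assay. For the measured compounds named here, the only step between two measured neighbours, a step that the two limits leave unreadable from compound 2 to compound 3, cannot be read, since both ends are limits. Compound 4 `CCOc1ccccc1Nc1nc(SCc2ccc(C(F)(F)F)cc2)nc2ccccc12` differs from compound 3 by ethoxy in place of trifluoromethyl on an aromatic carbon. Going by the values given here, no measured step covers an ethoxy in place of a trifluoromethyl, and the single step that exists gives no size and no direction, so nothing in the data points to a step in this assay beyond the scatter. The step from compound 3 to compound 4 is therefore estimated as a step that the limit leaves unreadable from compound 3 to compound 4, which is to say none that can be read. Compound 4 is expected to give 60000 nM in this assay, with a range from 20000 nM to 200000 nM, and most probably it will again be reported only as a limit.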

Compound 4, half-maximal inhibitory concentration: > 50000 nM
Compound 4 gave a limit, no number; the forecaster's own chance of this, stated with the estimate: 85%; the middle value lies beyond the limit too.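

Compound 4 gives > 50000 nM in this assay, a limit of the assay. The steps from compound 2 and from compound 3 to compound 4 join limits and cannot be read. The compounds shown leave open whether any change on the shared core alters the read-out, with every value at one limit: the limit of > 50000 nM in this assay, at which 4 of the 4 values shown sit.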